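Trading an Octyl Chain for a Cyclopentyl Ring

The source may report more compounds than this note shows. Statements on the series, on what has been measured and on what is new or still open speak of the compounds shown alone.

Compound 1 `CCN(CC)C(=O)C1C(=O)N(O)C(=O)c2ccccc21` and compound 2 `CCCCCCCCNC(=O)C1C(=O)N(O)C(=O)c2ccccc21` share one core and differ only in the group on the amide-type nitrogen. In an ADME assay on MT4 cells (Homo sapiens) for cytotoxicity, read by MTT assay (on this read-out lower numbers stand for higher toxicity in this test and higher numbers for lower toxicity in this test), compound 1 gives 28000 nM, while compound 2 gives 98500 nM; compound 2 thus holds the higher of the two numbers, by a gap beyond the usual scatter. Compound 3 `O=C(NC1CCCC1)C1C(=O)N(O)C(=O)c2ccccc21` is compound 2 with cyclopentyl in place of octyl on an amide-type nitrogen. Going by the values given here, no measured pair shows this change, so the expected step of a 1.6-fold lower number from compound 2 to compound 3 (0.22 log units; within the scatter) in this assay is a modest decline, barely beyond the scatter. Compound 3 is estimated at 60000 nM, within 20000 nM to 150000 nM.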

Compound 3, half-maximal cytotoxic concentration: > 250000 nM
Compound 3: a limit, no number; the forecaster's own chance of this, stated with the estimate: 20%; middle value at least 4.1-fold (0.61 log units) from the limit.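

In this assay compound 3 gives > 250000 nM, which is a limit of the assay and not a number. Cyclopentyl in place of octyl on this amide-type nitrogen still gives an at least 2.5-fold higher number from compound 2 to compound 3 (0.40 log units; beyond the scatter), so a ring with fewer carbons moves the read-out toward lower toxicity in this test rather than away from it. Cyclopentylamino in place of diethylamino gives an at least 8.9-fold higher number from compound 1 to compound 3 (0.95 log units; beyond the scatter). As far as these compounds go, what stays open is whether the ring or the shorter carbon count matters here. A pentyl chain on the same nitrogen would separate the two, and a cyclohexyl ring would test the ring size.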